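Aryl exchange on the ring nitrogen of compound 3

This account rests on a few compounds, and the source may have more. Where it says the series, first, only, none or still open, it means among the compounds named here.

Compound 3 `Cc1cc(=O)n(-c2ccccc2C(F)(F)F)nc1C(=O)Nc1ccc(Oc2ncnc3sccc23)c(F)c1` gives 16300 nM in a functional assay on A549 cells (Homo sapiens) for cytotoxicity, read by MTT assay, with a stated time of 72 h; a lower number here means a stronger inhibitor, a higher number a weaker inhibitor. Among the three measured compounds it holds the second highest number; its nearest neighbour is compound 2 `Cc1cc(=O)n(-c2ccccc2C(F)(F)F)nc1C(=O)Nc1ccc(Oc2ncnc3sccc23)cc1` with 19900 nM, the furthest is compound 1 `CNC(=O)c1cc(Oc2ccc(NC(=O)c3nn(-c4ccc(C)cc4)c(=O)cc3C)cc2F)ccn1` with 11500 nM, and both gaps are within the scatter. Within the data shown here, the only measured step, a 1.2-fold lower number from compound 2 to compound 3 (0.09 log units; within the scatter), concerns a fluoro in place of hydrogen on an aromatic carbon and stayed within the scatter.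

Compound 4 `Cc1ccc(-n2nc(C(=O)Nc3ccc(Oc4ncnc5sccc45)c(F)c3)c(C)cc2=O)cc1` carries the change (4-methylphenyl in place of 2-(trifluoromethyl)phenyl on an aromatic nitrogen). Among the measured compounds shown here, no measured pair covers this exchange of aryl groups. For the measured compounds named here, compound 1 carries the same 4-methylphenyl on its core but differs from compound 3 in other parts as well, so the values of compound 1 and compound 3 show only that the two numbers sit within the scatter of each other. The step of a 1.2-fold lower number from compound 2 to compound 3 (0.09 log units; within the scatter) does not touch the aryl group and gives no direction. The expected step of a 1.2-fold lower number from compound 3 to compound 4 (0.07 log units; within the scatter) is estimated to be none beyond the scatter. Compound 4 is therefore estimated at 14000 nM, with an expected range from 5000 nM to 40000 nM.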

Compound 4, half-maximal inhibitory concentration: > 40000 nM
Compound 4 was reported as a limit; the forecaster's own chance of this, stated with the estimate: 10%; at least 2.8-fold (0.45 log units) between middle value and limit.
By their numbers in this assay, from the lowest: compounds 1, 3 and 2 (each within the scatter of the next). At a limit, above all of these: compound 4.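

In this assay compound 4 is reported only as a limit, not as a number: the limit of > 40000 nM in this assay, at which 1 of the 4 values shown sits.

Among these compounds, the aryl group on the aromatic nitrogen is thus not freely exchangeable: 4-methylphenyl in place of 2-(trifluoromethyl)phenyl gives an at least 2.4-fold higher number from compound 3 to compound 4 (0.38 log units; beyond the scatter), whereas the only earlier step, the fluoro exchange, stayed within the scatter. With 4-methylphenyl held constant on that nitrogen, the group on the oxygen on an aromatic ring also counts, as the exchange there gives an at least 3.4-fold higher number from compound 1 to compound 4 (0.54 log units; beyond the scatter).

Going by these compounds, both steps rest on a limit, so their full size stays open. Also open, on these data alone, is how a plain phenyl, or a phenyl bearing an amine or a carboxylic acid, would read on that nitrogen.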